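Rearranging the side chain of a nitro compound

The compounds below may be only part of what the source reports. "The series", "measured", "known", "first", "only" and "open" are said of these compounds alone.

In a functional assay (Trachealis) with Cavia porcellus as the target (a higher number here means that more compound is needed for the effect, a lower number that less compound is needed), compound 1 `C/N=C(/NC#N)C1=CC(C)(C)Oc2ccc(C#N)cc21`, with a cyano group on the shared core, gives 646 nM. Compound 2 `C/N=C(/NC#N)C1=CC(C)(C)Oc2ccc([N+](=O)[O-])cc21`, with a nitro group there, gives 23.4 nM, which is a 28-fold lower number from compound 1 to compound 2 (1.44 log units; beyond the scatter). Compound 3 `CC/N=C(/NC#N)C1=CC(C)(C)Oc2ccc([N+](=O)[O-])cc21`, with one more methyl on the side chain, gives 170 nM, the second highest of the three numbers. That methyl brought a 7.3-fold higher number from compound 2 to compound 3 (0.86 log units; beyond the scatter).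

Compound 4 `CN(C)/C(=N\C#N)C1=CC(C)(C)Oc2ccc([N+](=O)[O-])cc21` has the same atoms as compound 3, joined differently: a group of 7 heavy atoms (4 carbon, 3 nitrogen; no ring) in place of a group of 7 heavy atoms (4 carbon, 3 nitrogen; no ring), on a double-bonded ring carbon. The counts differ only in hydrogen-bond donors. The closest guide is the modest side-chain step, a 7.3-fold higher number from compound 2 to compound 3 (0.86 log units; beyond the scatter). The large step, a 28-fold lower number from compound 1 to compound 2 (1.44 log units; beyond the scatter), lies elsewhere on the molecule and says little here. Among the compounds with values here, no measured step removes a hydrogen-bond donor, so the uncertainty is wide. A further rise of modest size, beyond the scatter, is expected. The expected change is a 5.9-fold higher number from compound 3 to compound 4 (0.77 log units; beyond the scatter). Compound 4 is estimated at 1000 nM, with an expected range from 200 nM to 6000 nM.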

Compound 4, half-maximal effective concentration: 51.3 nM
Estimate against measurement, compound 4: 19-fold (1.29 log units) above, and the stated range ends above it.
By their numbers in this assay, from the lowest: compound 2; then compound 4; then compound 3; then compound 1.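

Within this assay, how the atoms are joined on the double-bonded ring carbon matters, and not only how many there are: the same atoms in a new arrangement give a lower number (a 3.3-fold lower number from compound 3 to compound 4 (0.52 log units; beyond the scatter)). The group that enters has 0 hydrogen-bond donors where the group that leaves has 1, so a group without such a donor at this place can still give a number close to that of compound 2, though the gap remains beyond the scatter (a 2.2-fold higher number from compound 2 to compound 4 (0.34 log units; beyond the scatter)). Nothing available explains why this arrangement fares better than that of compound 3.

As far as these compounds go, it remains open whether a longer chain, such as propyl, or a pyrrolidine ring built on this nitrogen would keep the number low. From the compounds shown here alone, it is also open whether the same rearrangement behaves alike with the cyano group of compound 1 on the shared core.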